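Indazole biaryl series: amide for ethyl

The source may report more compounds than this note shows. Statements on the series, on what has been measured and on what is new or still open speak of the compounds shown alone.

Measured so far:
compound 1 `Fc1cccc(-c2ccc3[nH]ncc3c2)c1C(F)(F)F`: 8900 nM
compound 2 `CCc1cc2[nH]ncc2cc1-c1ccccc1C(F)(F)F`: 50 nM

Two compounds have been run in an assay on CHO-TREX cells for antagonist activity at transient receptor potential cation channel subfamily A member 1 (Homo sapiens), read by FLIPR and calcium flux, with a stated time of 10 min; a higher number here means a weaker inhibitor, a lower number a stronger inhibitor. Compound 1 `Fc1cccc(-c2ccc3[nH]ncc3c2)c1C(F)(F)F` gives 8900 nM in this assay. Compound 2 `CCc1cc2[nH]ncc2cc1-c1ccccc1C(F)(F)F` gives 50 nM in this assay, the lowest of the two numbers; the gap to compound 1 lies beyond the scatter, and the two structures differ in more than one place, so no single step can be read from the pair.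

Compound 3 `CNC(=O)c1cc2[nH]ncc2cc1-c1ccccc1C(F)(F)F` is the next one for this assay. The change from compound 2 is methylcarbamoyl in place of ethyl on an aromatic carbon. Among the measured compounds shown here, no measured pair shows this kind of change, so there is no precedent to lean on. The expectation is a step from compound 2 to compound 3 of a 10-fold higher number from compound 2 to compound 3 (1.00 log units; beyond the scatter), toward a weaker inhibitor, with considerable uncertainty in both directions. Compound 3 is thus estimated at 500 nM in this assay, within a range from 100 nM to 4000 nM.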

Compound 3, half-maximal inhibitory concentration: > 30000 nM
Compound 3: a limit, no number; the forecaster's own chance of this, stated with the estimate: 10%; middle value at least 60-fold (1.77 log units) from the limit.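

In this assay, among the compounds shown here, methylcarbamoyl in place of ethyl on this aromatic carbon, ortho to a large group, gives an at least 600-fold higher number from compound 2 to compound 3 (2.77 log units; beyond the scatter), the first step that can be read at a single place. Compound 3 gives > 30000 nM, which is a limit of the assay and not a number, so the step has a lower bound but no upper one: the limit of > 30000 nM in this assay, at which 1 of the 3 values shown sits. The pair of compound 1 and compound 2 differs in more than one place and could not isolate any position, whereas this pair shows that a change at this one aromatic carbon can, on its own, produce a step of this size.

This single step cannot separate the contributions of the larger group, the hydrogen-bond donor, the hydrogen-bond acceptor and the double bond that enter with methylcarbamoyl. From the compounds shown here alone, it also remains open whether a dimethylcarbamoyl group, a methoxy group or a propyl chain on this aromatic carbon would give a value closer to that of compound 2 or to the limit of compound 3.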